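Swapping a Side Chain on an Amino-Acid Ester

The source may report more compounds than this note shows. Statements on the series, on what has been measured and on what is new or still open speak of the compounds shown alone.

Compound 1 `NC(=O)C[C@H](NC(=O)CN(c1nc(Cl)nc2[nH]cnc12)C1CC1)C(=O)O`: 43.1%
Compound 2 `C[C@@H](O)[C@H](NC(=O)CN(c1ncnc2c1ncn2C1CCCCO1)C1CC1)C(=O)OCc1ccccc1`: 28.4%
Compound 3 `CC[C@H](C)[C@H](NC(=O)CN(c1nc(Cl)nc2[nH]cnc12)C1CC1)C(=O)OCc1ccccc1`: 40.6%

Of the compounds shown here, three have been measured in a functional assay on the whole organism (Tail, strain ICR) with Mus musculus as the target, in the tail flick test, with a stated time of 60 min, at a dose of 25 umol/kg by the oral route; a higher number here means a stronger effect of the compound at the dose given, a lower number a weaker effect. Compound 2 stands lowest of the three; the nearest value, that of compound 3, lies above it by more than the usual scatter, and the value of compound 1 lies further above still. Compound 2 and the other two also differ in their core, so its lower number cannot be tied to any single part of the structure.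

Compound 4 `N=C(N)NCCC[C@H](NC(=O)CN(c1ncnc2c1ncn2C1CCCCO1)C1CC1)C(=O)OCc1ccccc1` keeps the core and the benzyl ester of compound 2 and changes only the side chain of the amino-acid part: a group of 7 heavy atoms (4 carbon, 3 nitrogen; no ring) in place of a group of 3 heavy atoms (2 carbon, 1 oxygen; no ring), on a saturated chain carbon bound to an amide-type nitrogen and a carbonyl carbon. Within the data shown here, no measured pair shows what such a swap does on this core. Compounds 1 and 3, which carry quite different side chains on another core, sit close to one another, which hints that this position may tolerate change. For compound 4 the expected value is estimated at 33%, with a likely range from 15% to 52%. That estimate means an expected step of a number 4.6 percentage points higher from compound 2 to compound 4 (within the scatter), a small rise that would stay within the usual scatter.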

Compound 4, a percentage reported as activity, at one dose (the size of the read-out at that dose, not a potency): 52.4%
Compound 4: middle estimate off by 19.4 percentage points, on the low side, and the stated range ends below it.
By their numbers in this assay, from the lowest: compound 2; then compounds 3, 1 and 4 (each within the scatter of the next, the first and the last beyond it).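

Among these compounds, on the shared core with its benzyl ester, compounds 2 and 4 differ in one place only, so this pair gives the first direct reading of the side chain of the amino-acid part in this assay. Placing the open-chain group of 7 heavy atoms where 1-hydroxyethyl stood gives a number 24 percentage points higher from compound 2 to compound 4 (beyond the scatter), so a change at this position alone can move the effect by more than the usual scatter. No measurement at hand explains this rise.

A single pair cannot show which feature of the new group matters, and a plain amine or a carboxylic acid on a chain of similar length would help to separate them. On these data alone, it also remains open whether the same swap would give a similar step on the core of compound 3.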